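Fluoro to Bromo: Expected Shift in Cell Toxicity

The source may hold more compounds than are shown below. What is called first, only, known or untested is meant among the compounds shown, and "the series" means these compounds.

Measured compounds:
compound 1, `O=C(N/N=C/c1ccccc1Cl)c1cnccn1`: 70%
compound 2, `O=C(N/N=C/c1ccccc1F)c1cnccn1`: 100%

In an ADME assay on J774 cells (Mus musculus) for cytotoxicity, read by MTT assay, with a stated time of 48 h, tested at 50 ug/mL (a lower number here means a stronger effect, a higher number a weaker effect of the compound at the concentration tested), compound 2 stands highest of the two numbers, and its nearest neighbour is compound 1, reached by the step of a number 30 percentage points higher from compound 1 to compound 2 (beyond the scatter). Compound 3, `O=C(N/N=C/c1ccccc1Br)c1cnccn1`, differs from compound 2 by bromo in place of fluoro on an aromatic carbon. Going by the values given here, the only measured step bearing on this change is the same exchange on that aromatic carbon, a number 30 percentage points higher from compound 1 to compound 2 (beyond the scatter), which was modest. Among the compounds with values here, no measured pair compares fluoro with bromo directly, so the chloro result serves as the nearer guide, and a modest downward step is expected for compound 3: a number 28 percentage points lower from compound 2 to compound 3 (beyond the scatter). Compound 3 is therefore estimated at 72%, between 50% and 95%.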

Compound 3, a percentage reported as activity, at one concentration (the size of the read-out at that concentration, not a potency): 98%
Estimate against measurement, compound 3: 26 percentage points below; measured number above the stated range.
By their numbers in this assay, from the lowest: compound 1; then compounds 3 and 2 (each within the scatter of the next).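

In this assay, bromo in place of fluoro on this aromatic carbon leaves the read-out within the scatter (a number 2 percentage points lower from compound 2 to compound 3 (within the scatter)), whereas bromo in place of chloro moves it beyond the scatter (a number 28 percentage points higher from compound 1 to compound 3 (beyond the scatter)). The step from chloro to fluoro alone could not show that bromo would group with fluoro, leaving the chloro compound, compound 1, apart from the other two. Nothing available explains why chloro alone differs. Going by these compounds, whether a methoxy group or an amine on this carbon would group with fluoro and bromo or with chloro remains open, as does whether these halogens would behave the same way elsewhere on the ring.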